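A few compounds are considered here, and "the series" means these few. Any claim that something is new, unique, unknown or untested is made for them only; others in the source may bear on it.

In a physicochemical assay for solubility, with a stated time of 24 h, at pH 6.8 (a lower number here means a less soluble compound, a higher number a more soluble compound), compound 1 (`O=C(NC[C@@H]1[C@H]2CN(C(=O)/C=C/c3cc(Cl)cc(Cl)c3)C[C@@H]12)c1ccc2[nH]c(=O)oc2c1`) gives < 1 ug/mL as a limit of the assay and not a number. Compound 2 (`O=C(NC[C@@H]1[C@H]2CN(C(=O)C3CC3c3cc(Cl)cc(Cl)c3)C[C@@H]12)c1ccc2[nH]c(=O)oc2c1`) gives < 1 ug/mL as a limit too. Compound 3 (`O=C(NC[C@@H]1[C@H]2CN(C(=O)OCc3cc(C(F)(F)F)cc(C(F)(F)F)c3)C[C@@H]12)c1ccc2[nH]c(=O)oc2c1`) likewise gives < 1 ug/mL as a limit. The evidence so far is the limit of < 1 ug/mL in this assay, at which 3 of the 3 values shown sit, and no readable number exists yet. Among the compounds with values here, the only measured step, a step that the two limits leave unreadable from compound 1 to compound 2 offers no size to carry over. Compound 4 (`Cc1ccc(COC(=O)N2C[C@@H]3[C@@H](CNC(=O)c4ccc5[nH]c(=O)oc5c4)[C@@H]3C2)nc1`) carries the change a group of 9 heavy atoms (7 carbon, 1 nitrogen, 1 oxygen; one six-membered aromatic ring with 1 hetero atom) in place of a group of 10 heavy atoms (8 carbon, 2 chlorine; one six-membered aromatic ring of carbon only), on a carbonyl carbon in which the entering group holds no chlorine. A modest upward step is expected, resting on that change alone and on compound 1 sitting at < 1 ug/mL as a limit. The estimated step is an at least 8.0-fold higher number from compound 1 to compound 4 (0.90 log units; beyond the scatter) with a result at the limit still possible. Compound 4 is expected at 8 ug/mL within an estimated range of 1 ug/mL to 60 ug/mL in this assay here.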

Compound 4, solubility: 56 ug/mL
Compound 4: the middle estimate sits 7.0-fold (0.85 log units) below what was measured; the range from low to high includes it.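

In this assay, the group on the carbonyl carbon proves able to lift the series off its floor, with an at least 56-fold higher number from compound 1 to compound 4 (1.74 log units; beyond the scatter) and an at least 56-fold higher number from compound 2 to compound 4 (1.74 log units; beyond the scatter) when a group with a six-membered aromatic ring with 1 hetero atom and no chlorine enters. The step between the two earlier limits cannot be read, so compound 4 gives the first readable number against this background: the limit of < 1 ug/mL in this assay, at which 3 of the 4 values shown sit.

These steps do not separate the ring nitrogen from the loss of chlorine. From the compounds shown here alone, how an amine or a carboxylic acid at this place would read remains open.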